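This account rests on a few compounds, and the source may have more. Where it says the series, first, only, none or still open, it means among the compounds named here.

Compound 1 `CCCCCC(=O)NCc1ccc(C(=O)N[C@H](C(=O)O)[C@@H](C)CC)cc1`, compound 2 `CCCCCCCCCC(=O)NCc1ccc(C(=O)N[C@H](C(=O)O)[C@@H](C)CC)cc1` and compound 3 `CCCCCCCCCCCC(=O)NCc1ccc(C(=O)N[C@H](C(=O)O)[C@@H](C)CC)cc1` share one core and differ only in the length of the saturated chain on the amide. In a toxicity assay on cells (Erythrocyte, Homo sapiens) for cytotoxicity, read by hemolysis (a higher number here means that more compound is needed for the effect, a lower number that less compound is needed), compound 1 gives > 1500 ug/mL, which is a limit of the assay rather than a number. In this assay compound 2 gives > 1000 ug/mL, again a limit. In this assay, within the data shown here, compound 3 gives 400 ug/mL, the only plain number among the three. The change hexyl in place of hydrogen on a saturated chain carbon, five bonds along the chain from a carbonyl carbon gives an at least 3.7-fold lower number from compound 1 to compound 3 (0.57 log units; beyond the scatter), and an at least 2.5-fold lower number from compound 2 to compound 3 (0.39 log units; beyond the scatter) points the same way. The change from compound 1 to compound 2 is butyl in place of hydrogen on a saturated chain carbon, five bonds along the chain from a carbonyl carbon, and it yields a step that the two limits leave unreadable from compound 1 to compound 2; the two limits the limit of > 1000 ug/mL in this assay, at which 1 of the 3 values shown sits, and the limit of > 1500 ug/mL in this assay, at which 1 of the 3 values shown sits, leave its size open.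

Compound 4 `CCCCCCCCCCCCCCCC(=O)NCc1ccc(C(=O)N[C@H](C(=O)O)[C@@H](C)CC)cc1` has not been measured. Among the measured compounds shown here, the change butyl in place of hydrogen on a saturated chain carbon, ten or more bonds along the chain from a carbonyl carbon is the same kind of change as the one from compound 1 to compound 2, but it sits at a different place along the chain. Because an at least 3.7-fold lower number from compound 1 to compound 3 (0.57 log units; beyond the scatter) and an at least 2.5-fold lower number from compound 2 to compound 3 (0.39 log units; beyond the scatter) both lower the number as the chain grows, the step from compound 3 to compound 4 in this assay is expected to be a 2.7-fold lower number from compound 3 to compound 4 (0.43 log units; beyond the scatter). Compound 4 is estimated at 150 ug/mL, between 40 ug/mL and 500 ug/mL.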

Compound 4, half-maximal effective concentration: 50 ug/mL
Beside the measured number, compound 4's estimate is 3.0-fold (0.48 log units) above it; low and high end bracket the measured number.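

In this assay, the new result extends the trend seen at the long end of the series: butyl in place of hydrogen on a saturated chain carbon, ten or more bonds along the chain from a carbonyl carbon gives an 8.0-fold lower number from compound 3 to compound 4 (0.90 log units; beyond the scatter), while the wider comparisons give an at least 20-fold lower number from compound 2 to compound 4 (1.30 log units; beyond the scatter) and an at least 30-fold lower number from compound 1 to compound 4 (1.47 log units; beyond the scatter). Hexyl in place of hydrogen lowers the number on both the core of compound 1 and the core of compound 2, so the direction of this change carries over between these two cores, although its place along the chain differs. The size of the effect is a different matter, and these data do not show whether it carries over: the same change on two cores in this assay, an at least 3.7-fold lower number (0.57 log units; beyond the scatter) from compound 1 to compound 3 and an at least 20-fold lower number (1.30 log units; beyond the scatter) from compound 2 to compound 4; the limit leaves it open whether they differ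

The compounds shown leave open whether a longer chain would lower the number further or whether the trend would level off. They also leave open what a ring in place of the chain would do.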